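Oxabicyclic diacid amides: carboxy extension of the propyl chain

A few compounds are considered here, and "the series" means these few. Any claim that something is new, unique, unknown or untested is made for them only; others in the source may bear on it.

Compound 1 `CCCNC(=O)C1C(C(=O)O)[C@@H]2CC[C@H]1O2` is a bicyclic acid carrying a propyl amide on the shared core. In an ADME assay on A2780 cells (Homo sapiens) for cytotoxicity, read by MTT assay, with a stated time of 72 h (on this read-out lower numbers stand for stronger inhibition of growth and higher numbers for weaker inhibition of growth), compound 1 gives 10000 nM. Compound 2 `O=C(O)C1C(C(=O)Nc2ccc(CO)cc2)[C@H]2CC[C@@H]1O2` keeps the same core and acid but replaces the propyl amide with an anilide bearing a hydroxymethyl group; in this assay compound 2 gives 10000 nM. The two values sit level within the scatter, so on the numbers shown compound 1 stands together with compound 2, and no step between measured compounds is available to guide the series.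

Compound 3 `O=C(O)CCCNC(=O)C1C(C(=O)O)[C@@H]2CC[C@H]1O2` differs from compound 1 by the change (carboxy in place of hydrogen on a saturated chain carbon, three bonds along the chain from an amide-type nitrogen). Within the data shown here, with no measured step that isolates this kind of change, the expectation rests only on the fact that two different amide substituents, in compound 1 and compound 2, gave the same weak growth inhibition. The step of no change at the digits printed from compound 1 to compound 3 (within the scatter) is therefore expected to be none beyond the scatter. For compound 3 in this assay the estimate is 10000 nM, with a range from 5000 nM to 20000 nM.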

Compound 3, concentration for 50% growth inhibition: 10000 nM
Beside the measured number, compound 3's estimate shows no gap at the digits printed; low and high end bracket the measured number.
By their numbers in this assay, from the lowest: compounds 1, 2 and 3 (each within the scatter of the next).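

In this assay, carboxy in place of hydrogen on a saturated chain carbon, three bonds along the chain from an amide-type nitrogen, gives no change at the digits printed from compound 1 to compound 3 (within the scatter). Among these compounds, this is the first step that isolates a single change, and it shows that, on the shared core, propyl to 3-carboxypropyl leaves the read-out level within the scatter, which the different amide substituents of compound 1 and compound 2 could not show as a one-place comparison. No measurement shown offers an explanation for this flat result.

Open, as far as these compounds go, is whether an amine or a methyl ester in place of the carboxy, or a longer chain carrying the carboxy, would also read level with compound 1 in this assay. With only one step available, and that one within the scatter, the compounds shown do not yet identify any change on the amide substituent that moves growth inhibition beyond the scatter.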